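A few compounds are considered here, and "the series" means these few. Any claim that something is new, unique, unknown or untested is made for them only; others in the source may bear on it.

Measured compounds in this set:
compound 1 `COc1ccn2nc(C)c(C(=O)NCc3ccc(N4CCC(c5ccc(OC(F)(F)F)cc5)CC4)cc3)c2c1` — > 100000 nM
compound 2 `Cc1nn2ccc(-c3ccccc3)cc2c1C(=O)NCc1ccc(N2CCC(c3ccc(OC(F)(F)F)cc3)CC2)cc1` — "not determined" (no result reported)

Working notes. The series is assessed in an ADME assay on Vero cells (Chlorocebus sabaeus) for cytotoxicity, read by CCK-8 assay, with a stated time of 72 h; on this read-out higher numbers stand for weaker inhibition and lower numbers for stronger inhibition. For compound 1 the entry is a limit of the assay, not a number: in this assay compound 1 gives > 100000 nM. For compound 2 this assay reports "not determined" (no result reported), so no number stands beside it. Compound 1 therefore sits at the limit where one of the two entries shown rests (the limit of > 100000 nM in this assay, at which 1 of the 2 values shown sits), and nothing in the data places it on a numerical scale.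

The unmeasured compound 3 `CCc1nn2ccc(Cl)cc2c1C(=O)NCc1ccc(N2CCC(c3ccc(OC(F)(F)F)cc3)CC2)cc1` keeps the amide and the piperidinyl-phenyl part of compound 1 and changes the core: a group of 12 heavy atoms (9 carbon, 2 nitrogen, 1 chlorine; one five-membered aromatic ring with 2 hetero atoms, one six-membered aromatic ring with 1 hetero atom) in place of a group of 12 heavy atoms (9 carbon, 2 nitrogen, 1 oxygen; one five-membered aromatic ring with 2 hetero atoms, one six-membered aromatic ring with 1 hetero atom), on a carbonyl carbon — a group of 12 heavy atoms (9 carbon, 2 nitrogen, 1 chlorine; one five-membered aromatic ring with 2 hetero atoms, one six-membered aromatic ring with 1 hetero atom) in place of a group of 12 heavy atoms (9 carbon, 2 nitrogen, 1 oxygen; one five-membered aromatic ring with 2 hetero atoms, one six-membered aromatic ring with 1 hetero atom), on a carbonyl carbon.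

Among the measured compounds shown here, no step between two measured compounds is available, so no measured step size guides this change. Given that compound 1 reaches only a limit in this assay, > 100000 nM, the expected step from compound 1 to compound 3 is a number no higher from compound 1 to compound 3 (the limit leaves the size open), that is, none beyond the scatter, with a further limit as the most probable outcome. Compound 3 is expected to give about 100000 nM in this assay, estimated between 30000 nM and 300000 nM.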

Compound 3, half-maximal inhibitory concentration: > 100000 nM
Compound 3 gave a limit, no number; the forecaster's own chance of this, stated with the estimate: 70%; the middle value sits exactly at the limit.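

Compound 1 and compound 3 both rest at a limit, not a number, in this assay, so no step between them can be read: the limit of > 100000 nM in this assay, at which 2 of the 3 values shown sit.

The compounds shown leave open whether any change to the core of compound 1 would give a numerical value in this assay, and how large such a step would be.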